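The source may report more compounds than this note shows. Statements on the series, on what has been measured and on what is new or still open speak of the compounds shown alone.

Three compounds were examined in a functional assay on the whole organism for antagonist activity, with Mus musculus as the target; on this read-out higher numbers stand for an effect only at larger amounts of compound and lower numbers for an effect already at smaller amounts. Compound 1 `NCC(=O)NCC(=O)Nc1ccc([N+](=O)[O-])cc1C(=O)c1ccccc1` gave 4.82 mg/kg, and compound 2 `NCC(=O)NCC(=O)Nc1ccc([N+](=O)[O-])cc1C(=O)c1ccccc1Cl` gave 2.64 mg/kg. The two are related by a single change, (hydrogen in place of chloro on an aromatic carbon), and the step between them was a 1.8-fold higher number from compound 2 to compound 1 (0.26 log units; within the scatter). Compound 3 `CN(C(=O)CNC(=O)c1ccccc1)c1ccc(Cl)cc1C(=O)c1ccccc1Cl` gave 2.9 mg/kg in this assay, a value close to that of compound 2. How the core of compound 3 differs from that of compound 2 is not broken down here. Among the measured compounds shown here, compound 4 `CN(C(=O)CNC(=O)c1ccccc1)c1ccc(Cl)cc1C(=O)c1ccccc1` has not yet been measured; it arises from compound 3 by hydrogen in place of chloro on an aromatic carbon, the same change at the same place as the one leading from compound 2 to compound 1. Beside that earlier step, compound 4 is expected to show a 1.7-fold higher number from compound 3 to compound 4 (0.22 log units; within the scatter) in this assay because compound 1 stands at 4.82 mg/kg after the same change. The estimate for compound 4 is 4.8 mg/kg, expected between 2.4 mg/kg and 9.5 mg/kg.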

Compound 4, dose for half-maximal effect: 7.6 mg/kg
Beside the measured number, compound 4's estimate is 1.6-fold (0.20 log units) below it; low and high end bracket the measured number.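

In this assay, the change from 2-chlorophenyl to phenyl gave a 2.6-fold higher number from compound 3 to compound 4 (0.42 log units; beyond the scatter). Set beside the earlier step, the size of the change cannot be told apart on the two cores: the same change on two cores in this assay, a 1.8-fold higher number (0.26 log units; within the scatter) from compound 2 to compound 1 and a 2.6-fold higher number (0.42 log units; beyond the scatter) from compound 3 to compound 4, 1.4-fold (0.16 log units) apart, within the scatter of two such steps. Among the compounds shown here, this fits a change that carries over between these two cores, but it does not fix a general size for it: two cores are a narrow base, and only the step on the core of compound 3 stands clear of the scatter.

The compounds shown leave open whether fluoro, methyl or methoxy in place of the chloro would read like chloro or like hydrogen. They also leave open whether the step would hold on a core bearing a carboxylic acid or a nitrile.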